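The source may report more compounds than this note shows. Statements on the series, on what has been measured and on what is new or still open speak of the compounds shown alone.

Measured so far:
compound 1 `COCCOC(=O)C(O)Cn1cnc2c(N)ncnc21` — > 400 ug/mL
compound 2 `CCCOC(=O)C(O)Cn1cnc2c(N)ncnc21` — > 400 ug/mL

In a functional assay on Vero cells (Chlorocebus sabaeus) for cytotoxicity (on this read-out higher numbers stand for lower toxicity in this test and lower numbers for higher toxicity in this test), compound 1 gives only a limit, > 400 ug/mL. In this assay compound 2 also gives only a limit, > 400 ug/mL. Both values sit at the limit of > 400 ug/mL in this assay, at which 2 of the 2 values shown sit, so the step that the two limits leave unreadable from compound 1 to compound 2 stays unreadable. Compound 2 therefore stands at the limit and not at a number.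

Compound 3 `Nc1ncnc2c1ncn2CC(O)C(=O)OCc1ccco1` differs from compound 2 by furan-2-yl in place of ethyl on a saturated chain carbon bound to an oxygen next to a carbonyl group. Within the data shown here, the single measured step gives no readable size, so no shift beyond the scatter is expected for a number no higher from compound 2 to compound 3 (the limit leaves the size open). Compound 3 is expected at 400 ug/mL, between 200 ug/mL and 800 ug/mL, most probably reported again only as a limit.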

Compound 3, minimum cytotoxic concentration: 40 ug/mL
Compound 3: middle estimate off by 10-fold (1.00 log units), on the high side; the measured number lies below the stated range.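

In this assay, this position, a saturated chain carbon bound to an oxygen next to a carbonyl group, proves sensitive to the group it carries: furan-2-yl in place of ethyl gives an at least 10-fold lower number from compound 2 to compound 3 (1.00 log units; beyond the scatter), and furan-2-yl in place of methoxymethyl gives an at least 10-fold lower number from compound 1 to compound 3 (1.00 log units; beyond the scatter). Among these compounds, the step between the two earlier compounds cannot be read, so these are the first readable changes at this place. Their full size stays open, since both starting values are limits: the limit of > 400 ug/mL in this assay, at which 2 of the 3 values shown sit.

As far as these compounds go, whether the lower number goes with furan-2-yl specifically or with any aromatic ring remains open. Also open, from the compounds shown here alone, is how a phenyl ring or a longer chain such as butyl would read at this place.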